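A few compounds are considered here, and "the series" means these few. Any claim that something is new, unique, unknown or untested is made for them only; others in the source may bear on it.

In a functional assay on OVCAR-3 cells (Homo sapiens) for cytotoxicity, read by sulforhodamine B assay (on this read-out higher numbers stand for lower toxicity in this test and lower numbers for higher toxicity in this test), compound 1 `CC1=CC[C@@H]([C@@](C)(O)CCCC(C)(C)NC(=S)NN)CC1` gives only a limit, > 100000 nM. Among the compounds with values here, compound 2 `COc1ccc(/C=N\NC(=S)NC(C)(C)CCC[C@](C)(O)[C@@H]2CC=C(C)CC2)cc1` gives 46200 nM, the only true number so far. Within the data shown here, the one measured step is an at least 2.1-fold lower number from compound 1 to compound 2 (0.33 log units; beyond the scatter), and it brought in the whole group that holds the aromatic ring. Compound 3 `CC1=CC[C@@H]([C@@](C)(O)CCCC(C)(C)NC(=S)N/N=C\c2ccc(Cl)cc2)CC1` keeps that ring but changes 4-methoxyphenyl to 4-chlorophenyl, with chloro in place of methoxy on an aromatic carbon, para to a large group (chloro in place of methoxy on an aromatic carbon). Among the measured compounds shown here, no measured step tests this swap directly. For the measured compounds named here, the only guide is compound 2, reached by an at least 2.1-fold lower number from compound 1 to compound 2 (0.33 log units; beyond the scatter) through a far larger change, so no step beyond the scatter is expected here, in either direction. The expected change is a 1.2-fold lower number from compound 2 to compound 3 (0.06 log units; within the scatter). For compound 3 the estimated value is 40000 nM, with an expected range from 15000 nM to 100000 nM.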

Compound 3, concentration lethal to 50% of the cells: 40600 nM
For compound 3 the middle estimate is 1.0-fold (0.01 log units) below the measured one, and the stated range covers the measured number.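

In this assay, chloro in place of methoxy gives a 1.1-fold lower number from compound 2 to compound 3 (0.06 log units; within the scatter), so on this aromatic carbon, para to a large group, the two groups cannot be told apart. The drop from the core of compound 1 also holds with chloro, at an at least 2.4-fold lower number from compound 1 to compound 3 (0.39 log units; beyond the scatter), so it does not hang on the methoxy alone. That step gives only a minimum size and not a true one, since compound 1 gives only a limit: the limit of > 100000 nM in this assay, at which 1 of the 3 values shown sits.

With only methoxy and chloro shown at this place, it remains open whether an amine, a carboxylic acid or a nitrile there would move the number beyond the scatter. Going by these compounds, it also remains open whether the aromatic ring is needed at all, or whether a plain methyl group in its place would do as well.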